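Fluorine on the Pendant Aryl of a Lactone Reductase Inhibitor

This account rests on a few compounds, and the source may have more. Where it says the series, first, only, none or still open, it means among the compounds named here.

Three compounds of a shared core were measured in an assay for inhibition of 3-hydroxy-3-methylglutaryl-coenzyme A reductase (Rattus norvegicus); a lower number here means a stronger inhibitor, a higher number a weaker inhibitor. Compound 1 `Cc1ccccc1-c1cc(Cl)cc(Cl)c1/C=C/[C@@H]1C[C@@H](O)CC(=O)O1` gives 370 nM, the second highest of the three numbers. Compound 2 `CO[C@H]1CC(=O)O[C@H](/C=C/c2c(C)cc(C)cc2-c2ccc(F)c(C)c2)C1` gives 106 nM, a lower number than compound 1 beyond the scatter, while compound 3 `O=C1C[C@H](O)C[C@@H](/C=C/c2c(F)cc(F)cc2-c2ccc(F)cc2)O1` gives 860 nM, a higher number than compound 1, also beyond the scatter. Compound 4 `Cc1cc(F)ccc1-c1cc(Cl)cc(Cl)c1/C=C/[C@@H]1C[C@@H](O)CC(=O)O1` is not yet measured. It differs from compound 1 only in that (fluoro in place of hydrogen on an aromatic carbon), so that 2-methylphenyl becomes 4-fluoro-2-methylphenyl. Going by the values given here, no measured pair shows this change alone, so compound 4 is expected to give a number close to compound 1, with a step of a 1.3-fold lower number from compound 1 to compound 4 (0.12 log units; within the scatter) that may not exceed the scatter. Compound 4 is estimated at 280 nM, within 110 nM to 700 nM.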

Compound 4, half-maximal inhibitory concentration: 36 nM
Estimate against measurement, compound 4: 7.8-fold (0.89 log units) above; the whole stated range lies above it.
By their numbers in this assay, from the lowest: compound 4; then compound 2; then compound 1; then compound 3.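

In this assay, going by these compounds alone, fluoro in place of hydrogen on an aromatic carbon, para to a large group and meta to a methyl group, gives a 10-fold lower number from compound 1 to compound 4 (1.01 log units; beyond the scatter) and so provides the first direct reading of this position. Within the data shown here, a single added fluorine atom on the 2-methylphenyl group is enough for a large step, which the earlier compounds, differing in several places, could not show. Nothing measured here accounts for the size of this step.

As far as these compounds go, whether chloro, methoxy or hydroxyl at this position would give a similar step remains open. So does whether fluoro would do so without the methyl group.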